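The source may hold more compounds than are shown below. What is called first, only, known or untested is meant among the compounds shown, and "the series" means these compounds.

Measured compounds in a functional assay on HCT-15 cells (Homo sapiens) for antiproliferative activity, read by sulforhodamine B assay, with a stated time of 72 h; on this read-out lower numbers stand for stronger inhibition and higher numbers for weaker inhibition:
compound 1 `COc1cc(/C=C/COC(C)=O)ccc1OC(C)=O`, 3260 nM
compound 2 `CC[C@H](C)C(=O)Oc1ccc(/C=C/COC(C)=O)cc1OC`, 4580 nM
compound 3 `CCCC(=O)OC/C=C/c1ccc(OC(=O)CCC)c(OC)c1`, 28800 nM

Of these three, compound 3 gives the highest number; compound 2 comes nearest and compound 1 lies furthest, and both gaps are beyond the scatter. Compound 4 `CCCC(=O)Oc1ccc(/C=C/COC(C)=O)cc1OC` differs from compound 3 by hydrogen in place of ethyl on a saturated chain carbon bound to a carbonyl carbon. Within the data shown here, only one measured step exists, a 1.4-fold higher number from compound 1 to compound 2 (0.15 log units; within the scatter), and it concerns the ester on the other side of the molecule, so it bears on compound 4 only indirectly: it shows that compounds 1 and 2, which both carry the acetoxy group found in compound 4, sit close together in this assay. Compound 4 is therefore expected to move toward compound 2, a downward step a 4.1-fold lower number from compound 3 to compound 4 (0.61 log units; beyond the scatter) beyond the scatter. Compound 4 is estimated at 7000 nM, within 3000 nM to 20000 nM.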

Compound 4, half-maximal inhibitory concentration: 17100 nM
Beside the measured number, compound 4's estimate is 2.4-fold (0.39 log units) below it; measured number inside the range.
By their numbers in this assay, from the lowest: compounds 1 and 2 (each within the scatter of the next); then compounds 4 and 3 (each within the scatter of the next).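

In this assay, the change from propylcarbonyl to acetyl at this ester gives a 1.7-fold lower number from compound 3 to compound 4 (0.23 log units; within the scatter) and so does not separate the two compounds. The steps beyond the scatter fall on the other ester, with ethyl in place of hydrogen giving a 5.2-fold higher number from compound 1 to compound 4 (0.72 log units; beyond the scatter) and hydrogen in place of methyl giving a 3.7-fold higher number from compound 2 to compound 4 (0.57 log units; beyond the scatter) as the two modest shifts in this set. No measurement here accounts for these steps. Still open, on these data alone, is whether a longer chain or an amine at either ester would move the number, since only these short acyl groups appear.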